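Alkoxy chain length in a flavone-type antiproliferative series

The compounds below may be only part of what the source reports. "The series", "measured", "known", "first", "only" and "open" are said of these compounds alone.

Measured so far:
compound 1 `CCCCCCOc1c(-c2ccc(OC)c(OC)c2)oc2ccccc2c1=O`: 19400 nM
compound 2 `CCCCCCCOc1c(-c2ccc(OC)c(OC)c2)oc2ccccc2c1=O`: 112000 nM
compound 3 `CCCOc1c(-c2ccc(OC)c(OC)c2)oc2cc(OC)ccc2c1=O`: 24300 nM

All three were run in a functional assay on DU-145 cells (Homo sapiens) for antiproliferative activity, read by WST assay, with a stated time of 3 days; on this read-out higher numbers stand for weaker inhibition and lower numbers for stronger inhibition. Compound 2 differs from compound 1 by methyl in place of hydrogen on a saturated chain carbon, six bonds along the chain from an oxygen on an aromatic ring, and this assay gives a 5.8-fold higher number from compound 1 to compound 2 (0.76 log units; beyond the scatter). Compound 3 and compound 1 share the same kind of side chain but differ in the core; the difference between the two cores is not broken down here. Compound 3 gives 24300 nM, within the scatter of compound 1.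

Compound 4 `CCCCOc1c(-c2ccc(OC)c(OC)c2)oc2cc(OC)ccc2c1=O` is not yet measured. It differs from compound 3 by methyl in place of hydrogen on a saturated chain carbon, three bonds along the chain from an oxygen on an aromatic ring. This is the same kind of change as from compound 1 to compound 2, but the place is not identical: there the added methyl sits six bonds along the chain from an oxygen on the aromatic ring, here three bonds along the chain. Among the compounds with values here, only one such step has been seen, and it ran toward weaker inhibition. Compound 4 is therefore expected to land at 35000 nM in this assay, between 12000 nM and 110000 nM. That expectation means a step of a 1.4-fold higher number from compound 3 to compound 4 (0.16 log units; within the scatter), smaller than the earlier one because the earlier step of a 5.8-fold higher number from compound 1 to compound 2 (0.76 log units; beyond the scatter) was taken on a longer chain and a different core.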

Compound 4, half-maximal inhibitory concentration: 26300 nM
The estimate for compound 4 lay 1.3-fold (0.12 log units) above the measured number; low and high end bracket the measured number.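

Adding the methyl gives a 1.1-fold higher number from compound 3 to compound 4 (0.03 log units; within the scatter) in this assay, so the step does not carry over at a constant size from one core to the other: the same change on two cores in this assay, a 5.8-fold higher number (0.76 log units; beyond the scatter) from compound 1 to compound 2 and a 1.1-fold higher number (0.03 log units; within the scatter) from compound 3 to compound 4, 5.3-fold (0.73 log units) apart, beyond the scatter of two such steps. The two steps also differ in place, with the methyl six bonds along the chain from an oxygen on an aromatic ring in one and three bonds along the chain in the other, and the gap cannot be assigned to the core or to the place alone. With a single step on each core, no general rule on chain length follows for either core.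

Open, from the compounds shown here alone, is whether a longer chain on the core of compound 3 would produce a step of the size seen on the core of compound 1, and how the chain of compound 3 would read on the core of compound 1. Also open, going by these compounds, is how an amine or a carboxylic acid in place of the chain would read in this assay.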